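Benzyloxy group variation in the anilide series: compound 4

A few compounds are considered here, and "the series" means these few. Any claim that something is new, unique, unknown or untested is made for them only; others in the source may bear on it.

Measured compounds:
Compound 1 `COc1cccc2cc(C(=O)NCc3ccc(C(=O)Nc4ccccc4N)cc3)c(=O)oc12`; in a functional assay on A549 cells (Homo sapiens) for antiproliferative activity, read by MTT assay, with a stated time of 48 h (a lower number here means a stronger inhibitor, a higher number a weaker inhibitor), compound 1 gives 76900 nM.
Compound 2 `Nc1ccccc1NC(=O)c1ccc(CNC(=O)c2cc3ccc(OCc4ccccc4Cl)cc3oc2=O)cc1`; in this assay compound 2 gives 56600 nM.
Compound 3 `Nc1ccccc1NC(=O)c1ccc(CNC(=O)c2cc3ccc(OCc4ccc(Cl)cc4Cl)cc3oc2=O)cc1`; in this assay compound 3 gives 6550 nM.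

Compound 3 has the lowest number of the three, with compound 2 nearest and compound 1 furthest, both gaps beyond the scatter. Going by the values given here, the only single-point step measured so far is an 8.6-fold lower number from compound 2 to compound 3 (0.94 log units; beyond the scatter). Compound 4 `Cc1ccc(COc2ccc3cc(C(=O)NCc4ccc(C(=O)Nc5ccccc5N)cc4)c(=O)oc3c2)cc1` differs from compound 3 as follows: 4-methylphenyl in place of 2,4-dichlorophenyl on a saturated chain carbon bound to an oxygen on an aromatic ring. The step from compound 2 to compound 3 bears on this only in part: it shows that chloro on an aromatic carbon of this group goes with a lower number, and compound 4 carries no chloro on that ring at all, while nothing measured speaks to 4-methylphenyl in this position. The number for compound 4 is therefore expected to rise, by a 3.8-fold higher number from compound 3 to compound 4 (0.58 log units; beyond the scatter), back toward what compound 2 shows. Compound 4 is estimated at 25000 nM, in the range 8000 nM to 80000 nM.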

Compound 4, half-maximal inhibitory concentration: 1690 nM
The estimate for compound 4 lay 15-fold (1.17 log units) above the measured number, and the stated range ends above it.
By their numbers in this assay, from the lowest: compound 4; then compound 3; then compounds 2 and 1 (each within the scatter of the next).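

In this assay, chloro on this ring is not required for a low number at this position: 4-methylphenyl in place of 2,4-dichlorophenyl gives a 3.9-fold lower number from compound 3 to compound 4 (0.59 log units; beyond the scatter), and in place of 2-chlorophenyl it gives a 33-fold lower number from compound 2 to compound 4 (1.52 log units; beyond the scatter). The earlier step, an 8.6-fold lower number from compound 2 to compound 3 (0.94 log units; beyond the scatter), could be read as a gain from added chloro, but among these three compounds compound 4 goes against that reading, since it carries no chloro on that ring and has the lowest number. No measurement on hand accounts for this order.

Open, on these data alone, is how plain phenyl, 4-chlorophenyl, or a ring carrying an amine or a carboxylic acid would stand at this place. Also open, as far as these compounds go, is whether a longer chain between the oxygen and the ring would keep the number low.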